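The source may report more compounds than this note shows. Statements on the series, on what has been measured and on what is new or still open speak of the compounds shown alone.

Compound 1 `Cc1nc(N)nc2c1c(-c1ccc3oc(N)nc3c1)nn2C(C)C`. In an ADME assay on cells (Hepatocyte, Homo sapiens) for metabolic stability, read by LC-MS, with a stated time of 90 min, tested at 1 uM (on this read-out lower numbers stand for slow clearance and higher numbers for fast clearance), compound 1 gives < 5 uL/min, which is a limit of the assay and not a number.
Compound 2 `CC(C)n1nc(-c2ccc3oc(N)nc3c2)c2cnc(N)nc21`. In this assay compound 2 gives 150 uL/min.
Compound 3 `Cc1nc2c(c(-c3ccc4oc(N)nc4c3)nn2C(C)C)c(=O)[nH]1`. In this assay compound 3 gives < 5 uL/min, again a limit of the assay.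

Both limits sit at the limit of < 5 uL/min in this assay, at which 2 of the 3 values shown sit.

Compound 4 `CC(C)n1nc(-c2ccc3oc(N)nc3c2)c2c(=O)[nH]cnc21` has not yet been measured. From compound 1 to compound 2 the change is hydrogen in place of methyl on an aromatic carbon; it gave an at least 30-fold higher number from compound 1 to compound 2 (1.47 log units; beyond the scatter). From compound 3 to compound 4 the change is hydrogen in place of methyl on an aromatic carbon. This is the same kind of change, not the same: in compound 1 the methyl sits next to the ring nitrogen, ortho to a fused ring, meta to an amino group and opposite the ring nitrogen, whereas in compound 3 it sits between two ring nitrogen atoms, para to a fused ring and meta to a group of 1 heavy atom. The difference between the core of compound 1 and the core of compound 3 is not broken down here.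

Resting on an at least 30-fold higher number from compound 1 to compound 2 (1.47 log units; beyond the scatter), the expected step is an at least 4.0-fold higher number from compound 3 to compound 4 (0.60 log units; beyond the scatter). The uncertainty is wide; the change is of the same kind but the place differs. Compound 4 is estimated at 20 uL/min in this assay, between 4 uL/min and 100 uL/min.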

Compound 4, intrinsic clearance in a liver preparation (reported as CLH), per the amount of preparation that the assay uses in the Hepatocyte assay: < 5 uL/min
Compound 4: only a limit was reported (the forecaster's own chance of this, stated with the estimate: 30%); middle value at least 4.0-fold (0.60 log units) away from the limit.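

The step in the Hepatocyte assay between compound 3 and compound 4 cannot be read, because both compounds sit at a limit of the assay and not at a number: the limit of < 5 uL/min in the Hepatocyte assay, at which 3 of the 4 values shown sit.

In a physicochemical assay for solubility, read by HPLC, in phosphate buffer, measured as kinetic solubility, with a stated time of 24 h, at 20 degrees C, at pH 7.4, tested at 100 uM (a lower number here means a less soluble compound, a higher number a more soluble compound), compound 3 gives 3000 nM and compound 4 gives 3000 nM, which is no change at the digits printed from compound 3 to compound 4 (within the scatter).

Still open, going by these compounds, is whether hydrogen in place of methyl on the core of compound 3 alters clearance in the Hepatocyte assay at all.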